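The source may report more compounds than this note shows. Statements on the series, on what has been measured and on what is new or still open speak of the compounds shown alone.

In a functional assay on T47D cells (Homo sapiens) for inhibition, read by sulforhodamine B assay, with a stated time of 48 h (a lower number here means that less compound is tolerated, a higher number that more compound is tolerated), compound 1 `Nc1cc(N)c2nc(-c3ccccc3)c(Oc3ccc(Cl)c(Cl)c3)nc2c1` is known only as a limit, < 100000 nM. Compound 2 `CCOC(=O)[C@H](CCC(=O)O)NC(=O)c1ccc(Sc2nc3cc(N)cc(N)c3nc2-c2ccccc2)cc1` likewise stops at a limit, < 100000 nM. Among the compounds with values here, compound 3 `COc1ccc(CNc2nc3cc(N)cc(N)c3nc2-c2ccccc2)cc1` is the single compound with a number, giving 72400 nM. On the numbers shown, compound 1 therefore has no fixed place: two of the three values rest at the same boundary, (the limit of < 100000 nM in this assay, at which 2 of the 3 values shown sit), and compound 1 is one of them.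

Compound 4 `COc1ccc(Sc2nc3cc(N)cc(N)c3nc2-c2ccccc2)cc1` has not yet been measured. It differs from compound 1 in one place, ((4-methoxyphenyl)sulfanyl in place of 3,4-dichlorophenoxy on an aromatic carbon), with the new group sitting where the old one did, ortho to a phenyl group on the shared core. Within the data shown here, no step between two measured compounds is known in this set, so there is no measured guide to how such a swap shifts the value. What the three values do show is a set that clusters at or near the boundary of this assay, and compound 4 is expected to fall in the same region. The expected step that the limit leaves unreadable from compound 1 to compound 4 is estimated to be small, not clearly beyond the scatter of repeated measurements. Compound 4 is estimated at 60000 nM, within a range from 20000 nM to 150000 nM, with a real chance that only a limit is reported again.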

Compound 4, concentration lethal to 50% of the cells: < 100000 nM
Compound 4: no number, only a limit; the forecaster's own chance of this, stated with the estimate: 50%; the middle value is on the limit's open side.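

Compound 1 and compound 4 both stop at a limit rather than a number, so no step can be read for putting (4-methoxyphenyl)sulfanyl in place of 3,4-dichlorophenoxy in this assay: the limit of < 100000 nM in this assay, at which 3 of the 4 values shown sit.

The compounds shown leave open whether this swap changes the value at all, and if it does, in which direction and by how much.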